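Ester to Amide on a Weak Bile Acid Receptor Ligand

The source may hold more compounds than are shown below. What is called first, only, known or untested is meant among the compounds shown, and "the series" means these compounds.

Compound 1 `COC(=O)/C=C/c1cccc(N(Cc2ccc(-c3ccc(F)c(Cl)c3)cc2)C(=O)C2CCCCC2)c1` gives 66 nM in an assay on isolated protein with Bile acid receptor (Homo sapiens) as the target; a higher number here means that more compound is needed for the effect, a lower number that less compound is needed. Compound 2 `COC(=O)/C=C/c1ccc(CN(C(=O)C2CCCCC2)c2cccc(/C=C/C(=O)OC)c2)cc1` carries a second 2-(methoxycarbonyl)ethenyl arm in place of the 3-chloro-4-fluorophenyl group, and this costs activity: an at least 15-fold higher number from compound 1 to compound 2 (1.18 log units; beyond the scatter). For compound 2 only a limit was recorded, > 1000 nM, a limit of the assay (the limit of > 1000 nM in this assay, at which 1 of the 2 values shown sits). Compound 3 `COC(=O)/C=C/c1cccc(N(Cc2ccc(/C=C/C(=O)N(C)C)cc2)C(=O)C2CCCCC2)c1` alters that arm once more: dimethylamino in place of methoxy on a carbonyl carbon. Among the measured compounds shown here, no measured step covers this ester-to-amide change, so nothing anchors an expectation beyond the limit seen for compound 2. Compound 3 is therefore expected near 2000 nM, between 500 nM and 10000 nM, with a step that the limit leaves unreadable from compound 2 to compound 3 likely no step beyond the scatter.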

Compound 3, half-maximal effective concentration: > 1000 nM
Compound 3 was reported as a limit; the forecaster's own chance of this, stated with the estimate: 70%; the middle value does not contradict the limit.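

The loss at this position is not confined to the ester arm: 2-(dimethylcarbamoyl)ethenyl in place of 3-chloro-4-fluorophenyl also gives an at least 15-fold higher number from compound 1 to compound 3 (1.18 log units; beyond the scatter), so swapping methoxy for dimethylamino recovers no measurable activity. How the ester and the amide compare with each other cannot be read, because both compounds stand at a limit of the assay: the limit of > 1000 nM in this assay, at which 2 of the 3 values shown sit.

Any difference between these two arms therefore stays hidden. Also open, from the compounds shown here alone, is whether a carboxylic acid on this carbonyl carbon, or a simple phenyl ring in place of the arm, would bring activity back toward that of compound 1.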